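A few compounds are considered here, and "the series" means these few. Any claim that something is new, unique, unknown or untested is made for them only; others in the source may bear on it.

Three measured compounds share one core and differ only in the group on the sulfonamide nitrogen. Compound 1 is `N=C(N)NS(=O)(=O)c1ccc(N/C=C\C(=O)c2cc3ccccc3oc2=O)cc1`; in a functional assay on T47D cells (Homo sapiens) for cytotoxicity, read by sulforhodamine B assay, with a stated time of 48 h (a lower number here means a stronger inhibitor, a higher number a weaker inhibitor), compound 1 gives 87600 nM. Compound 2 is `Cc1noc(NS(=O)(=O)c2ccc(N/C=C\C(=O)c3cc4ccccc4oc3=O)cc2)c1C` and in this assay compound 2 gives 68400 nM. Compound 3 is `Cc1nnc(NS(=O)(=O)c2ccc(N/C=C\C(=O)c3cc4ccccc4oc3=O)cc2)s1` and in this assay compound 3 gives 94000 nM. On the numbers alone compound 1 sits second highest of the three, but a 1.3-fold lower number from compound 1 to compound 2 (0.11 log units; within the scatter) and a 1.1-fold higher number from compound 1 to compound 3 (0.03 log units; within the scatter) both lie within the scatter, so the three cannot be told apart.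

Compound 4 is `COc1cnc(NS(=O)(=O)c2ccc(N/C=C\C(=O)c3cc4ccccc4oc3=O)cc2)nc1`. It differs from compound 1 by a group of 8 heavy atoms (5 carbon, 2 nitrogen, 1 oxygen; one six-membered aromatic ring with 2 hetero atoms) in place of a group of 3 heavy atoms (1 carbon, 2 nitrogen; no ring), on a sulfonamide nitrogen. The two measured steps that bear on this also swap the same small group for an aromatic ring on the sulfonamide nitrogen, and neither moved the number beyond the scatter. The step to compound 4 is therefore expected to be a 1.0-fold lower number from compound 1 to compound 4 (0.01 log units; within the scatter), nothing beyond the scatter. Compound 4 is estimated at 85000 nM, within 40000 nM to 180000 nM.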

Compound 4, half-maximal inhibitory concentration: 8800 nM
The estimate for compound 4 lay 9.7-fold (0.98 log units) above the measured number; the whole stated range lies above it.
By their numbers in this assay, from the lowest: compound 4; then compounds 2, 1 and 3 (each within the scatter of the next).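

In this assay, for the compounds shown here, the group on the sulfonamide nitrogen proves able to change the number, which the earlier compounds did not show: 5-methoxypyrimidin-2-yl gives a 10-fold lower number from compound 1 to compound 4 (1.00 log units; beyond the scatter). The step holds against both five-membered aromatic rings, with an 11-fold lower number from compound 3 to compound 4 (1.03 log units; beyond the scatter) and a 7.8-fold lower number from compound 2 to compound 4 (0.89 log units; beyond the scatter), so an aromatic ring at this place is not enough on its own, as compound 2 and compound 3 show. No measurement is available to explain why this group stands apart from the others.

The methoxy group and the six-membered ring with its two nitrogens enter together, so the compounds shown leave open which of them carries the step. A plain pyrimidin-2-yl group and a 4-methoxyphenyl group on the same nitrogen would be the direct tests.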